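Trithiocarbonate Ketones Against HDAC6: A Chain Change

A few compounds are considered here, and "the series" means these few. Any claim that something is new, unique, unknown or untested is made for them only; others in the source may bear on it.

Measured so far:
- compound 1, `CCSC(=S)SCC(=O)c1ccc(C)cc1`: 1250 nM
- compound 2, `COCCSC(=S)SCC(=O)c1ccc(OC)cc1`: 2130 nM
- compound 3, `CCSC(=S)SCC(=O)c1cccc(S(=O)(=O)Nc2ccc(OC)cc2)c1`: 519 nM

The three compounds share a core in which a ketone-bearing aromatic ring is joined through a short chain to a trithiocarbonate, which in turn carries a second chain. In an assay on HEK293 cells for inhibition of protein deacetylase HDAC6 (Homo sapiens) (on this read-out lower numbers stand for stronger inhibition and higher numbers for weaker inhibition), compound 2 gives 2130 nM, the highest of the three numbers. The nearest value belongs to compound 1, whose 1250 nM lies within the scatter of compound 2, so the two cannot be placed in order. The furthest value belongs to compound 3, whose 519 nM lies beyond the scatter, so compound 3 is a stronger inhibitor than compound 2.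

Compound 4, `COc1ccc(C(=O)CSC(=S)SCCNC(C)=O)cc1`, has not yet been measured. It differs from compound 2 in a single place: acetamido in place of methoxy on a saturated chain carbon, two bonds along the chain from a sulfur. Among the compounds with values here, no pair of measured compounds differs in this way, so there is no measured step to lean on, and no other compound carries a change on this outer chain at all. The expectation is therefore a cautious one: a step from compound 2 that stays within the usual scatter, in no particular direction, is what is expected for a 1.0-fold lower number from compound 2 to compound 4 (0.01 log units; within the scatter). On that basis compound 4 is estimated to give 2100 nM in this assay, with a range from 700 nM to 6300 nM.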

Compound 4, half-maximal inhibitory concentration: 1640 nM
For compound 4 the middle estimate is 1.3-fold (0.11 log units) above the measured one; the measured number falls inside the stated range.
By their numbers in this assay, from the lowest: compound 3; then compounds 1, 4 and 2 (each within the scatter of the next).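

In this assay, the outer chain now has its first measured step: acetamido in place of methoxy on a saturated chain carbon, two bonds along the chain from a sulfur, reads as a 1.3-fold lower number from compound 2 to compound 4 (0.11 log units; within the scatter). In this single pair, the entering acetamido group has more heavy atoms than methoxy and brings a hydrogen-bond donor that methoxy lacks, yet the two compounds cannot be told apart on this read-out, so this position can carry either group without a measurable difference. Nothing available here explains this result or links it to any measured property of the two groups.

The compounds shown leave open whether a free amine or a carboxylic acid at this position, or a longer chain in place of the 2-acetamidoethyl group, would also stay within the scatter of compound 2. Within the data shown here, they also leave open whether the same exchange would read the same way on the core of compound 3, which holds the lowest number so far.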